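Ethylamino in Place of Methylamino on a Second Core

The source may report more compounds than this note shows. Statements on the series, on what has been measured and on what is new or still open speak of the compounds shown alone.

The measured compounds:
compound 1, `CNCC(=O)Nc1cc(OC)ccc1C(=O)c1ccc(OC)c2c1OC(C)(C)C=C2`, 820 nM
compound 2, `CNCC(=O)Nc1cc(OC)ccc1C(=O)c1ccc2c(c1)C=CC(C)(C)O2`, 1210 nM
compound 3, `CCNCC(=O)Nc1cc(OC)ccc1C(=O)c1ccc(OC)c2c1OC(C)(C)C=C2`, 5200 nM

In a functional assay on MCF7 cells (Homo sapiens) for antiproliferative activity, read by MTT assay, with a stated time of 48 h (on this read-out higher numbers stand for weaker inhibition and lower numbers for stronger inhibition), compound 1 gives 820 nM, and compound 3 gives 5200 nM. Compound 3 carries methyl in place of hydrogen on a saturated chain carbon bound to an amine nitrogen relative to compound 1, and this change made a 6.3-fold higher number from compound 1 to compound 3 (0.80 log units; beyond the scatter). Compound 2 has a different core; the difference between the two cores is not broken down here. In this assay compound 2 gives 1210 nM, which lies within the scatter of compound 1. Compound 4, `CCNCC(=O)Nc1cc(OC)ccc1C(=O)c1ccc2c(c1)C=CC(C)(C)O2`, is not yet measured and carries methyl in place of hydrogen on a saturated chain carbon bound to an amine nitrogen relative to compound 2, the same change at the same place as from compound 1 to compound 3. Because that change made a 6.3-fold higher number from compound 1 to compound 3 (0.80 log units; beyond the scatter), a step of about a 5.4-fold higher number from compound 2 to compound 4 (0.73 log units; beyond the scatter) is expected here. Compound 4 is estimated at 6500 nM, between 2500 nM and 16000 nM.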

Compound 4, half-maximal inhibitory concentration: 6310 nM
Compound 4: middle estimate off by 1.0-fold (0.01 log units), on the high side; low and high end bracket the measured number.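

On the core of compound 2, ethylamino in place of methylamino gave a 5.2-fold higher number from compound 2 to compound 4 (0.72 log units; beyond the scatter) in this assay. The step therefore carried from one core to the other at much the same size: the same change on two cores in this assay, a 6.3-fold higher number (0.80 log units; beyond the scatter) from compound 1 to compound 3 and a 5.2-fold higher number (0.72 log units; beyond the scatter) from compound 2 to compound 4, 1.2-fold (0.08 log units) apart, within the scatter of two such steps. This rests on just two cores and one cell assay, so it does not show that the step would hold on any other core or in any other assay, nor does it explain why the number rises.

The compounds shown leave open how a longer chain such as propylamino, a branched isopropylamino or a plain primary amine would read in this assay. They also leave open whether any of these would follow the same course on both cores.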